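Dimethylcarbamoyl Chain in Place of Acryloyl Azetidine

The source may report more compounds than this note shows. Statements on the series, on what has been measured and on what is new or still open speak of the compounds shown alone.

The compounds here share one core and differ only in the side chain that hangs from an oxygen on an aromatic ring. Compound 1 `O=C(/C=C/CNCCOc1ccc(Oc2c(-c3ccc(F)cc3)sc3cc(O)ccc23)cc1)N1CCCC1` carries a 3-((pyrrolidin-1-yl)carbonyl)prop-2-en-1-yl group on an amine nitrogen in that chain. In a functional assay on MDA-MB-231 cells (Homo sapiens) for antiproliferative activity, read by CCK-8 assay, with a stated time of 48 h (on this read-out higher numbers stand for weaker inhibition and lower numbers for stronger inhibition), compound 1 gives > 50000 nM, which is a limit of the assay rather than a number. Compound 2 `C/C=C/C(=O)NCCOc1ccc(Oc2c(-c3ccc(F)cc3)sc3cc(O)ccc23)cc1` replaces that group with (prop-1-en-1-yl)carbonyl, and in this assay compound 2 gives > 50000 nM, again only a limit. Compound 3 `C=CC(=O)N1CC(Oc2ccc(Oc3c(-c4ccc(F)cc4)sc4cc(O)ccc34)cc2)C1` shortens the chain to 1-(vinylcarbonyl)azetidin-3-yl; in this assay compound 3 gives > 50000 nM, once more a limit. The two steps, a step that the two limits leave unreadable from compound 1 to compound 2 and a step that the two limits leave unreadable from compound 2 to compound 3, therefore carry no readable size, since every value sits at the limit of > 50000 nM in this assay, at which 3 of the 3 values shown sit.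

Compound 4 `CN(C)C(=O)/C=C/CNCCOc1ccc(Oc2c(-c3ccc(F)cc3)sc3cc(O)ccc23)cc1` makes the change (2-((3-(dimethylcarbamoyl)prop-2-en-1-yl)amino)ethyl in place of 1-(vinylcarbonyl)azetidin-3-yl on an oxygen on an aromatic ring). Compound 4 resembles compound 1 more closely than compound 3, exchanging only the ring of the amide for two methyl groups, and compound 1 gives no number either. Within the data shown here, no step here shows a direction, so compound 4 is expected to stay near the limit, with the step that the limit leaves unreadable from compound 3 to compound 4 estimated as essentially none. Compound 4 is estimated at 60000 nM, within 15000 nM to 200000 nM.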

Compound 4, half-maximal inhibitory concentration: > 50000 nM
Compound 4: no number, only a limit (the forecaster's own chance of this, stated with the estimate: 85%); the middle value is on the limit's open side.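

Compound 4 also gives only a limit of the assay and not a number, so its steps from compound 1, compound 2 and compound 3 cannot be read, and all four compounds sit together: the limit of > 50000 nM in this assay, at which 4 of the 4 values shown sit. The compounds shown leave open whether any of these side chains differs from the others in this assay, since none gives a number.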